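The compounds below may be only part of what the source reports. "The series", "measured", "known", "first", "only" and "open" are said of these compounds alone.

Measured so far:
- compound 1, `Cc1nc(Nc2ccc(Cl)cc2)sc1C(=O)/C=C/c1ccccc1`: in a functional assay on NCI-H460 cells (Homo sapiens) for cytotoxicity, read by MTT assay (a lower number here means a stronger inhibitor, a higher number a weaker inhibitor), compound 1 gives > 25000 nM, a limit of the assay rather than a number.
- compound 2, `Cc1nc(Nc2cccc(Cl)c2)sc1C(=O)/C=C/c1ccccc1`: in this assay compound 2 gives > 25000 nM, again a limit rather than a number.

Compound 2 stands at the limit of > 25000 nM in this assay, at which 2 of the 2 values shown sit. Going by the values given here, the one step between measured compounds, a step that the two limits leave unreadable from compound 1 to compound 2, therefore gives no readable size: both ends are limits.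

Compound 3, `Cc1nc(Nc2ccc(Cl)c(Cl)c2)sc1C(=O)/C=C/c1ccccc1`, is not yet measured. It differs from compound 2 by chloro in place of hydrogen on an aromatic carbon. Among the compounds with values here, no measured step touches this position, so nothing in the numbers so far speaks for or against a change beyond the scatter; the only step on the aryl ring, the shift of the chloro group between compound 1 and compound 2, is itself unreadable.

The expected step is a step that the limit leaves unreadable from compound 2 to compound 3, which is to say no movement that the assay would resolve, with a limit the most likely outcome again. For compound 3 the estimate in this assay is 30000 nM, with an expected range from 8000 nM to 100000 nM.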

Compound 3, half-maximal inhibitory concentration: 22700 nM
For compound 3 the middle estimate is 1.3-fold (0.12 log units) above the measured one; the measured number falls inside the stated range.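

Chloro in place of hydrogen, on the aromatic carbon ortho to a chloro group and para to a large group, gives the first steps in this assay that can be read at all: an at least 1.1-fold lower number from compound 2 to compound 3 (0.04 log units; that floor lies within the scatter) and an at least 1.1-fold lower number from compound 1 to compound 3 (0.04 log units; that floor lies within the scatter). Both are floors rather than sizes, and neither floor goes beyond the scatter, so the change from 3-chlorophenyl to 3,4-dichlorophenyl is neither shown to matter nor ruled out as a real effect. The true size of both steps stays unknown because compound 1 and compound 2 give only limits, not numbers: the limit of > 25000 nM in this assay, at which 2 of the 3 values shown sit.

Still open, going by these compounds, is whether another group at this position, such as methoxy, an amine or a carboxylic acid, would give a number in this assay clearly apart from that of compound 3. Also open, on these data alone, is how the 3,4-dichlorophenyl compound would respond to a change elsewhere on the shared core, for instance a longer chain in place of the methyl group.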